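Amide ring variation on the sulfonyl-piperazine series

This account rests on a few compounds, and the source may have more. Where it says the series, first, only, none or still open, it means among the compounds named here.

Measured so far:
compound 1 `CC(C(=O)N1CCCCC1)N1CCN(S(=O)(=O)c2ccc(C(C)(C)C)cc2)CC1`, compound 2 `CC(C(=O)N1CCCCCC1)N1CCN(S(=O)(=O)c2ccc(C(C)(C)C)cc2)CC1`, compound 3 `CC(C(=O)N1CCc2ccccc2C1C)N1CCN(S(=O)(=O)c2ccc(C(C)(C)C)cc2)CC1`.

In an ADME assay on HepG2 cells (Homo sapiens) for inhibition, with a stated time of 48 h (a lower number here means that less compound is needed, a higher number that more compound is needed for the effect), compound 1 gives > 40000 nM, a limit of the assay. In this assay compound 2 gives > 40000 nM, also a limit. For the measured compounds named here, compound 3 gives 28000 nM and is thus the only compound with a number rather than a limit.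

Compound 4 `CC(C(=O)N1CCc2ncccc2C1)N1CCN(S(=O)(=O)c2ccc(C(C)(C)C)cc2)CC1` carries a group of 10 heavy atoms (8 carbon, 2 nitrogen; one six-membered non-aromatic ring with 1 hetero atom, one six-membered aromatic ring with 1 hetero atom) in place of a group of 11 heavy atoms (10 carbon, 1 nitrogen; one six-membered non-aromatic ring with 1 hetero atom, one six-membered aromatic ring of carbon only), on a carbonyl carbon. The steps that touch this position are an at least 1.4-fold lower number from compound 1 to compound 3 (0.15 log units; that floor lies within the scatter) and an at least 1.4-fold lower number from compound 2 to compound 3 (0.15 log units; that floor lies within the scatter), both truncated by the limit of > 40000 nM in this assay, at which 2 of the 3 values shown sit; neither shows a change beyond the scatter. No shift beyond the scatter is therefore expected for a 1.3-fold higher number from compound 3 to compound 4 (0.10 log units; within the scatter), and a limit is possible again.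

Compound 4 is expected at 35000 nM, with a range from 12000 nM to 120000 nM.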

Compound 4, half-maximal effective concentration: > 40000 nM
Compound 4 was reported as a limit; the forecaster's own chance of this, stated with the estimate: 50%; middle value at least 1.1-fold (0.05 log units) away from the limit.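

In this assay, the swap of 1-methyl-1,2,3,4-tetrahydroisoquinolin-2-yl for the group with a nitrogen in its aromatic ring gives an at least 1.4-fold higher number from compound 3 to compound 4 (0.15 log units; that floor lies within the scatter), so no change beyond the scatter is established at this position on the carbonyl carbon. The steps to compound 4 from the two simple ring amides cannot be read. For the compounds shown here, compound 3 remains the only compound with a number, and readings are truncated by the limit of > 40000 nM in this assay, at which 3 of the 4 values shown sit.

The step removes the methyl and adds the ring nitrogen together, leaving their separate contributions open. Going by these compounds, whether 1,2,3,4-tetrahydroisoquinolin-2-yl without the methyl, or a morpholin-4-yl amide, would give a number rather than a limit also stays open.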